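The source may report more compounds than this note shows. Statements on the series, on what has been measured and on what is new or still open speak of the compounds shown alone.

Of the compounds shown here, three built on one shared core have been measured so far: compound 1 `COc1cccc(NC(=O)COc2ccc3cc(/C=C4/SC(=O)NC4=O)ccc3c2)c1`, compound 2 `O=C(COc1ccc2cc(/C=C3/SC(=O)NC3=O)ccc2c1)Nc1cccc(F)n1` and compound 3 `Cc1cccc2sc(NC(=O)COc3ccc4cc(/C=C5/SC(=O)NC5=O)ccc4c3)nc12`. In an assay on isolated protein for inhibition of histone deacetylase 4 (Homo sapiens), with a stated time of 1 h (a higher number here means a weaker inhibitor, a lower number a stronger inhibitor), compound 1 gives 1600 nM, compound 2 gives 840 nM and compound 3 gives 1200 nM. Compound 2 holds the lowest of the three numbers, yet the gaps are small: a 1.9-fold lower number from compound 1 to compound 2 (0.28 log units; within the scatter) and a 1.4-fold higher number from compound 2 to compound 3 (0.15 log units; within the scatter) both fall within the scatter, so the three compounds cannot be told apart with confidence.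

Compound 4 `COc1ccc(NC(=O)COc2ccc3cc(/C=C4/SC(=O)NC4=O)ccc3c2)cc1` is the next compound. Its difference from compound 2 is 4-methoxyphenyl in place of 6-fluoropyridin-2-yl on an amide-type nitrogen. For the measured compounds named here, the step that bears on this is the one between compound 1 and compound 2, where a methoxyphenyl group on the amide-type nitrogen was exchanged for the group that now leaves again: a 1.9-fold lower number from compound 1 to compound 2 (0.28 log units; within the scatter). Reversing a change of that size, with the methoxy group now on a different position of the phenyl, is expected to give a 1.5-fold higher number from compound 2 to compound 4 (0.19 log units; within the scatter), a move not beyond the scatter. Compound 4 is therefore estimated at 1300 nM, with a range from 600 nM to 3000 nM.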

Compound 4, half-maximal inhibitory concentration: 4700 nM
For compound 4 the middle estimate is 3.6-fold (0.56 log units) below the measured one, and the stated range ends below it.
By their numbers in this assay, from the lowest: compounds 2, 3 and 1 (each within the scatter of the next); then compound 4.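

Until now, every exchange on the amide-type nitrogen stayed within the scatter, but this position can clearly respond to the group placed there: replacing 6-fluoropyridin-2-yl with 4-methoxyphenyl gives a 5.6-fold higher number from compound 2 to compound 4 (0.75 log units; beyond the scatter), and replacing 4-methyl-1,3-benzothiazol-2-yl with it gives a 3.9-fold higher number from compound 3 to compound 4 (0.59 log units; beyond the scatter). The closest comparison is 4-methoxyphenyl in place of 3-methoxyphenyl, which gives a 2.9-fold higher number from compound 1 to compound 4 (0.47 log units; beyond the scatter), so in this assay two groups with the same atoms but the methoxy group at different ring positions can be told apart. No measurement offered here explains this loss of strength.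

The compounds shown leave open whether the methoxy group in 4-methoxyphenyl itself weakens inhibition. A plain phenyl, or an amine or carboxylic acid in place of that methoxy group, could help settle this.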